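A few compounds are considered here, and "the series" means these few. Any claim that something is new, unique, unknown or untested is made for them only; others in the source may bear on it.

In an ADME assay on SH-SY5Y cells (Homo sapiens) for cytotoxicity, read by MTT assay, with a stated time of 48 h (a lower number here means a stronger inhibitor, a higher number a weaker inhibitor), three compounds have been measured so far. Compound 1 `COc1ccc(C(=O)/C=C/c2ccc(OCCCOc3ccccc3)c(OC)c2)c(O)c1` gives > 100000 nM, which is a limit of the assay and not a number. Compound 3 `COc1ccc(C(=O)/C=C/c2cc(OC)c(OC)c(OC)c2)c(O)c1` gives > 100000 nM, again a limit. Compound 2 `COc1ccc(C(=O)/C=C/c2ccc(C(=O)N3CCCC3)cc2)c(O)c1` gives > 100000 nM, also a limit. All three therefore share one position: the limit of > 100000 nM in this assay, at which 3 of the 3 values shown sit. For the measured compounds named here, compound 4 `COc1ccc(C(=O)/C=C/c2ccc(C(=O)N3CCCCC3)cc2)c(O)c1` has piperidin-1-yl in place of pyrrolidin-1-yl on a carbonyl carbon, its one change from compound 2: piperidin-1-yl in place of pyrrolidin-1-yl on a carbonyl carbon. Going by the values given here, no measured pair yet shows the effect of a single change, so no step beyond the usual scatter is expected, with the limit of compound 2, > 100000 nM, as the only anchor. The estimate for compound 4 is 100000 nM, with an expected range of 40000 nM to 200000 nM.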

Compound 4, half-maximal inhibitory concentration: > 100000 nM
Compound 4 gave a limit, no number; the forecaster's own chance of this, stated with the estimate: 85%; the middle value lies on the limit itself.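

Compound 2 and compound 4 each give only a limit, not a number, so no step can be read for piperidin-1-yl in place of pyrrolidin-1-yl. What structural change would produce a measurable value in this assay stays open, as every compound shown shares one position: the limit of > 100000 nM in this assay, at which 4 of the 4 values shown sit.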